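A few compounds are considered here, and "the series" means these few. Any claim that something is new, unique, unknown or untested is made for them only; others in the source may bear on it.

All three measured compounds share one core and differ only in the group attached beside the amino acid arm. Compound 1 `NC(C(=O)O)c1cnn(O)c1Br` carries a bromine there, and in a functional assay on CHO cells for agonist activity at metabotropic glutamate receptor 2 (Rattus norvegicus), read by cAMP accumulation (a higher number here means that more compound is needed for the effect, a lower number that less compound is needed), compound 1 gives 170000 nM; 151000 nM (2 entries) (the several entries of compound 1 in this assay, 170000 nM; 151000 nM (2 entries)). Compound 2 `CCc1c(C(N)C(=O)O)cnn1O` carries an ethyl chain, and in this assay compound 2 gives 57000 nM; 56200 nM (2 entries) (the several entries of compound 2 in this assay, 57000 nM; 56200 nM (2 entries)). Compound 3 `CCCCc1c(C(N)C(=O)O)cnn1O` carries a longer butyl chain. In this assay compound 3 gives only a limit of the assay, > 1000000 nM, not a measured number (the limit of > 1000000 nM in this assay, at which 1 of the 3 values shown sits), so compound 3 stands at the edge of what the assay can report, with no single number of its own.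

The step to compound 4 `NC(C(=O)O)c1cnn(O)c1CCc1ccccc1` is phenyl in place of ethyl on a saturated chain carbon, two bonds along the chain from an aromatic carbon: the chain keeps its anchor on the core and ends in a ring. Going from the ethyl of compound 2 to the butyl of compound 3 took the activity past the limit, and compound 4 carries a still larger group. The step from compound 3 to compound 4 is therefore expected to be small or none in this assay, an at least 1.2-fold lower number from compound 3 to compound 4 (0.09 log units; that floor lies within the scatter), with a real chance that the assay again reports only a limit. Compound 4 is estimated at 800000 nM, in a range from 150000 nM to 3000000 nM.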

Compound 4, half-maximal effective concentration: > 1000000 nM
Compound 4: only a limit was reported (the forecaster's own chance of this, stated with the estimate: 65%); at least 1.2-fold (0.09 log units) between middle value and limit.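

In this assay compound 4 gives only a limit, > 1000000 nM. Compound 3 also gives only a limit, > 1000000 nM. For the compounds shown here, no step between compound 3 and compound 4 can be read. Left open is where the real values of these two compounds lie, and so whether phenyl in place of ethyl changes anything.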